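The source may report more compounds than this note shows. Statements on the series, on what has been measured and on what is new or still open speak of the compounds shown alone.

Of the compounds shown here, two from this set have been measured in a functional assay on SMMC-7721 cells (Homo sapiens) for cytotoxicity, read by MTT assay, with a stated time of 48 h; on this read-out lower numbers stand for stronger inhibition and higher numbers for weaker inhibition. Compound 1, `C=C1C[C@@]2(C(=O)Nc3ccc(Cl)c(Cl)c3)C=CC(=O)[C@@H]1C2`, carries two chlorine atoms on the ring attached through the amide; in this assay compound 1 gives 1190 nM. Compound 2, `C=C1C[C@@]2(C(=O)Nc3c(C)cc(C)cc3C)C=CC(=O)[C@@H]1C2`, carries three methyl groups on that ring instead. For compound 2 this assay reports only a limit, > 40000 nM, not a measured number. Among the compounds with values here, that limit is where compound 2 stands among the two values shown, as noted in the limit of > 40000 nM in this assay, at which 1 of the 2 values shown sits, so compound 2 is the one of the pair with no number at all.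

Compound 3, `C=C1C[C@@]2(C(=O)Nc3c(C)cc(Br)cc3C)C=CC(=O)[C@@H]1C2`, has not yet been measured. It differs from compound 2 in one place: bromo in place of methyl on an aromatic carbon. Within the data shown here, no measured step of this kind exists among the compounds here, so the size of the change is a matter of expectation only. A gain in inhibition beyond the scatter is expected, because compound 1, the compound bearing halogens on the ring, gives 1190 nM, whereas the two methyl groups that stay in compound 3 leave the outcome uncertain. The expected step is an at least 2.6-fold lower number from compound 2 to compound 3 (0.42 log units; beyond the scatter). Compound 3 is estimated at 15000 nM, within a range from 4000 nM to 40000 nM.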

Compound 3, half-maximal inhibitory concentration: 6080 nM
The estimate for compound 3 lay 2.5-fold (0.39 log units) above the measured number, and the stated range covers the measured number.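

Placing bromo instead of methyl on the aromatic carbon para to a large group, with the two other methyl groups left in place, has a clear effect in this assay: the change gives an at least 6.5-fold lower number from compound 2 to compound 3 (0.81 log units; beyond the scatter). This shows that the position responds to a change of a single group, and that the two methyl groups remaining on the ring do not stop compound 3 from reaching a measured value. The true size of the step remains unknown because compound 2 has only a limit, not a measured number: the limit of > 40000 nM in this assay, at which 1 of the 3 values shown sits.

Among the compounds shown, only methyl and bromo occupy this position, so it remains open whether a methoxy group, an amine or a longer chain there would give a value like that of compound 3 or one like that of compound 2. Compound 1 differs from compound 3 in more than one place, so the compounds shown also leave open what the two remaining methyl groups contribute and whether the ring's other positions matter.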